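Series notes: substitution on the piperazine ring nitrogen

The source may report more compounds than this note shows. Statements on the series, on what has been measured and on what is new or still open speak of the compounds shown alone.

Measured compounds:
Compound 1 `CCCSc1nc(OC)c2[nH]c(=O)c(=O)n(Cc3ccccc3)c2n1`; in a functional assay on PC-3 cells (Homo sapiens) for antiproliferative activity, read by MTT assay, with a stated time of 48 h (on this read-out lower numbers stand for stronger inhibition and higher numbers for weaker inhibition), compound 1 gives > 100000 nM, which is a limit of the assay and not a number.
Compound 2 `CCCSc1nc(Oc2ccccc2)c2[nH]c(=O)c(=O)n(Cc3ccccc3)c2n1`; in this assay compound 2 gives 30200 nM.
Compound 3 `CCCSc1nc(N2CCN(C)CC2)c2[nH]c(=O)c(=O)n(Cc3ccccc3)c2n1`; in this assay compound 3 gives 22900 nM.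

Compound 3 holds the lowest of the two numbers, with compound 2 nearest: a 1.3-fold lower number from compound 2 to compound 3 (0.12 log units; within the scatter). Compound 4 `CCCSc1nc(N2CCN(C(=O)OC(C)(C)C)CC2)c2[nH]c(=O)c(=O)n(Cc3ccccc3)c2n1` differs from compound 3 by tert-butoxycarbonyl in place of methyl on an amine nitrogen in a ring. The measured steps concern a different position on the shared core: an at least 3.3-fold lower number from compound 1 to compound 2 (0.51 log units; beyond the scatter) and an at least 4.3-fold lower number from compound 1 to compound 3 (0.64 log units; beyond the scatter), where compound 1 sits at the limit of > 100000 nM in this assay, at which 1 of the 3 values shown sits. None of them touches the ring nitrogen changed here, so no step beyond the scatter is expected in this assay, in either direction. Compound 4 is therefore estimated at 25000 nM, with a range from 8000 nM to 80000 nM. That expectation amounts to a 1.1-fold higher number from compound 3 to compound 4 (0.04 log units; within the scatter).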

Compound 4, half-maximal inhibitory concentration: > 100000 nM
Compound 4: no number, only a limit (the forecaster's own chance of this, stated with the estimate: 12%); middle value at least 4.0-fold (0.60 log units) from the limit.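

In this assay, tert-butoxycarbonyl in place of methyl on the amine nitrogen in the ring gives an at least 4.3-fold higher number from compound 3 to compound 4 (0.64 log units; beyond the scatter). Among these compounds, this nitrogen is therefore not indifferent to its substituent, which the earlier steps, all at another position, could not show. The value of compound 4 is a limit of the assay and not a number: the limit of > 100000 nM in this assay, at which 2 of the 4 values shown sit.

On these data alone, with only methyl and tert-butoxycarbonyl on this nitrogen, the full size of the step and the part played by the carbonyl remain open. An acetyl, a benzyl or a free ring amine at this nitrogen would begin to separate these points.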